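This account rests on a few compounds, and the source may have more. Where it says the series, first, only, none or still open, it means among the compounds named here.

Measured compounds in a functional assay, with a stated time of 6 min; a lower number here means a stronger inhibitor, a higher number a weaker inhibitor:

compound 1, `FC(F)(F)c1cccc(NCn2nc(-c3ccc4c(c3)OCCO4)oc2=S)c1`: 7620 nM
compound 2, `S=c1oc(-c2ccc3c(c2)OCCO3)nn1CNc1cccc(Cl)c1`: 6220 nM
compound 3, `O=[N+]([O-])c1ccc(NCn2nc(-c3ccc4c(c3)OCCO4)oc2=S)c(Cl)c1`: 8660 nM

Compound 2 gives the lowest of the three numbers, but the other two stand very close to it. The step of a 1.2-fold lower number from compound 1 to compound 2 (0.09 log units; within the scatter) lies within the scatter, and the gap between compound 2 and compound 3 is likewise within the scatter, so none of the three can be called stronger or weaker than the others on these numbers.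

Compound 4, `Cc1ccccc1NCn1nc(-c2ccc3c(c2)OCCO3)oc1=S`, has not yet been measured. It differs from compound 2 in a single place: 2-methylphenyl in place of 3-chlorophenyl on an amine nitrogen. For the measured compounds named here, the only measured step that bears on this change is a 1.2-fold lower number from compound 1 to compound 2 (0.09 log units; within the scatter), which also exchanged one group for another on the ring attached to the amine nitrogen and produced no step beyond the scatter. Compound 3 gives 8660 nM, again within the scatter of compound 2. On this basis the step of a 1.1-fold higher number from compound 2 to compound 4 (0.05 log units; within the scatter) is expected to stay within the scatter. Compound 4 is therefore estimated at 7000 nM, with a range from 3000 nM to 16000 nM.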

Compound 4, half-maximal inhibitory concentration: 3450 nM
Beside the measured number, compound 4's estimate is 2.0-fold (0.31 log units) above it; measured number inside the range.
By their numbers in this assay, from the lowest: compounds 4, 2, 1 and 3 (each within the scatter of the next, the first and the last beyond it).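

In this assay, the step of a 1.8-fold lower number from compound 2 to compound 4 (0.26 log units; within the scatter) shows that this place on the amine nitrogen accepts 2-methylphenyl as well as 3-chlorophenyl, with no change that can be told from the scatter. Compound 4 extends the series to a ring whose added group holds carbon only, whereas the groups on the rings of compound 1, compound 2 and compound 3 all contain other elements, and here too the number stays within the scatter of compound 2. No measurement is available that would explain this result.

This step changes both the group and its place on the ring, so 3-methylphenyl and 2-chlorophenyl would be needed to separate those two changes. Going by these compounds, how plain phenyl, or a ring carrying an amine or a carboxylic acid, would behave at this place also remains open.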